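Removing both chlorines from the urea aryl group

A few compounds are considered here, and "the series" means these few. Any claim that something is new, unique, unknown or untested is made for them only; others in the source may bear on it.

Compound 2 `CN(C)CCNc1nc(-c2ccc(NC(=O)Nc3ccc(Cl)cc3Cl)cc2)nc2ccsc12` is one of two compounds tested in a functional assay on MKN-45 cells (Homo sapiens) for cytotoxicity, read by MTT assay, with a stated time of 72 h; on this read-out higher numbers stand for weaker inhibition and lower numbers for stronger inhibition. In this assay compound 2 gives 2360 nM, the higher of the two numbers. Compound 1 `CN(C)CCNc1nc(-c2ccc(NC(=O)Nc3ccc(Cl)cc3)cc2)nc2ccsc12` gives 250 nM in this assay, and the step of a 9.4-fold higher number from compound 1 to compound 2 (0.97 log units; beyond the scatter) came from a single added chlorine on the urea aryl group. Compound 3 `Cc1ccc(NC(=O)Nc2ccc(-c3nc(NCCN(C)C)c4sccc4n3)cc2)cc1` carries the change (4-methylphenyl in place of 2,4-dichlorophenyl on an amide-type nitrogen); this removes both chlorines and puts in a methyl group. The step from compound 1 to compound 2 bears on it directly, since undoing the added chlorine is part of the change; it was modest and should largely reverse, so a lower number is expected. Among the measured compounds shown here, no measured step covers swapping the remaining chlorine for methyl, so that part adds uncertainty. Compound 3 is therefore expected to give 350 nM in this assay, within 120 nM to 1200 nM, an expected step of a 6.7-fold lower number from compound 2 to compound 3 (0.83 log units; beyond the scatter).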

Compound 3, half-maximal inhibitory concentration: 2380 nM
For compound 3 the middle estimate is 6.8-fold (0.83 log units) below the measured one; measured number above the stated range.
By their numbers in this assay, from the lowest: compound 1; then compounds 2 and 3 (each within the scatter of the next).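

In this assay the exchange of 2,4-dichlorophenyl for 4-methylphenyl on the urea nitrogen gives a 1.0-fold higher number from compound 2 to compound 3 (0.00 log units; within the scatter) and so leaves the two groups indistinguishable here, even though one carries two chlorines and the other none. Methyl in place of chloro on an aromatic carbon gives a 9.5-fold higher number from compound 1 to compound 3 (0.98 log units; beyond the scatter) and shows that removing the added chlorine is not enough by itself: the low number of compound 1 is lost when its one remaining chlorine becomes methyl. Nothing available explains why these changes act as they do.

On these data alone, it remains open whether a plain phenyl group, with hydrogen in place of the chloro of compound 1, would hold that lower number. A fluoro, methoxy or trifluoromethyl group in the same place would test how specific the chloro is.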